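A Trifluoromethyl for Methyl Among Three Level Compounds

A few compounds are considered here, and "the series" means these few. Any claim that something is new, unique, unknown or untested is made for them only; others in the source may bear on it.

In a functional assay on HL-60 cells (Homo sapiens) for antiproliferative activity, read by MTT assay, with a stated time of 72 h (a lower number here means a stronger inhibitor, a higher number a weaker inhibitor), compound 1 (`CCn1cc(C(=O)O)c(=O)c2cc(F)c(N3CCN(C(=N)NS(=O)(=O)c4ccc(C(F)(F)F)cc4)CC3)cc21`) gives 43 nM and compound 2 (`Cc1ccc(S(=O)(=O)NC(=N)N2CCN(c3cc4c(cc3F)c(=O)c(C(=O)O)cn4C3CC3)CC2)cc1`) gives 43 nM while compound 3 (`CCn1cc(C(=O)O)c(=O)c2cc(F)c(N3CCN(C(=N)NS(=O)(=O)c4ccccc4)CC3)cc21`) gives 43 nM as well. Compound 2 therefore stands level with compounds 1 and 3, with no gap to either at the digits reported, and the three values offer no ranking.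

Compound 4 (`N=C(NS(=O)(=O)c1ccc(C(F)(F)F)cc1)N1CCN(c2cc3c(cc2F)c(=O)c(C(=O)O)cn3C2CC2)CC1`) has not yet been measured. It differs from compound 2 in one place (trifluoromethyl in place of methyl on an aromatic carbon): trifluoromethyl in place of methyl on an aromatic carbon, para to a large group, so that 4-methylphenyl becomes 4-(trifluoromethyl)phenyl.

For the measured compounds named here, no measured pair makes this exchange directly. Going by the values given here, the one measured step that bears on it also concerns trifluoromethyl on an aromatic carbon, where hydrogen takes the place of that group. Given the size of that step (no change at the digits printed from compound 1 to compound 3 (within the scatter)) the change expected in this assay (no change at the digits printed from compound 2 to compound 4 (within the scatter)) is none beyond the scatter, in either direction. This expectation rests on a single step and three equal values, so it remains tentative. In this assay the estimated value for compound 4 is 43 nM within an expected range of 21 nM to 88 nM for this compound.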

Compound 4, half-maximal inhibitory concentration: 43 nM
For compound 4 middle estimate and measured number coincide at the digits printed; measured number inside the range.
By their numbers in this assay, from the lowest: compounds 1, 2, 3 and 4 (each within the scatter of the next).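

In this assay, the direct exchange of trifluoromethyl in place of methyl, on an aromatic carbon para to a large group, reads no change at the digits printed from compound 2 to compound 4 (within the scatter) and so gives this position its first measured pair for that exchange, where only hydrogen in place of trifluoromethyl had been read before. Compound 4 also opens a second place to comparison: cyclopropyl in place of ethyl on an aromatic nitrogen reads no change at the digits printed from compound 1 to compound 4 (within the scatter) and leaves the trifluoromethyl-bearing pair level as well. Neither of these two places has yet separated any measured pair in this assay, although a level result at these few members sets no general rule, and no measurement at hand accounts for it.

Going by these compounds, whether any other group on this aromatic carbon would shift the value remains open, for instance a methoxy, an amine or a carboxylic acid in place of trifluoromethyl. The aromatic nitrogen is equally unexplored beyond ethyl and cyclopropyl, so a longer chain such as hexyl, or a benzyl group, might or might not stay level with these four compounds.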